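The source may hold more compounds than are shown below. What is called first, only, known or untested is meant among the compounds shown, and "the series" means these compounds.

In a functional assay on the whole organism (strain Albino Swiss CD1) with Mus musculus as the target (on this read-out lower numbers stand for an effect already at smaller amounts and higher numbers for an effect only at larger amounts of compound), compound 1 `CCC(C(=O)NCc1ccccc1)N1C(=O)CCC1=O` gives 90.3 mg/kg, and compound 2 `CCC(C(=O)NCc1ccc(Cl)cc1)N1C(=O)CCC1=O` gives 50.8 mg/kg. Compound 2 thus holds the lowest of the two numbers, but the step of a 1.8-fold lower number from compound 1 to compound 2 (0.25 log units; within the scatter) lies within the scatter, so the two compounds cannot be set apart on this read-out. Compound 3 `CCC(C(=O)NCc1ccc(C(F)(F)F)cc1)N1C(=O)CCC1=O` arises from compound 2 by a single change: trifluoromethyl in place of chloro on an aromatic carbon. Within the data shown here, the only measured step that bears on this change is the one from compound 1 to compound 2, in which a chloro replaced a hydrogen on an aromatic carbon and the number stayed within the scatter. Among the measured compounds shown here, no measured step shows the trifluoromethyl itself. The expectation is therefore no movement beyond the scatter, perhaps a small drift toward a lower number, giving an expected step of a 1.1-fold lower number from compound 2 to compound 3 (0.05 log units; within the scatter). Compound 3 is estimated to give about 45 mg/kg, with a range from 22 mg/kg to 90 mg/kg.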

Compound 3, dose for half-maximal effect: 80.4 mg/kg
Compound 3: middle estimate off by 1.8-fold (0.25 log units), on the low side, and the stated range covers the measured number.
By their numbers in this assay, from the lowest: compounds 2, 3 and 1 (each within the scatter of the next).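

At this place on the aromatic ring, para to a large group, this assay now has a second substituent to set against chloro: trifluoromethyl in place of chloro gives a 1.6-fold higher number from compound 2 to compound 3 (0.20 log units; within the scatter), and trifluoromethyl in place of hydrogen gives a 1.1-fold lower number from compound 1 to compound 3 (0.05 log units; within the scatter). Hydrogen, chloro and trifluoromethyl at this place therefore cannot be told apart on this read-out, so neither substituent has yet been shown to matter here. Nothing measured alongside these numbers offers a reason for this result.

The compounds shown leave open whether a group of another kind at this place, such as an amine or a carboxylic acid, would move the number beyond the scatter. They also leave open whether a longer chain elsewhere on the shared core would do so.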